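The source may report more compounds than this note shows. Statements on the series, on what has been measured and on what is new or still open speak of the compounds shown alone.

Measured compounds in a functional assay on MV4-11 cells (Homo sapiens) for inhibition, read by resazurin assay, with a stated time of 72 h; on this read-out higher numbers stand for weaker inhibition of growth and lower numbers for stronger inhibition of growth:
- compound 1 `Cc1ccc(-c2cncc(Cl)c2N2CCC3(CCNC3=O)CC2)o1`: 4950 nM
- compound 2 `O=Cc1ccc(-c2cncc(Cl)c2N2CCC3(CCNC3=O)CC2)o1`: 5190 nM

Within the data shown here, compound 2, at 5190 nM, stands level with compound 1, the only other measured compound, within the scatter. Compound 3 `Cc1ccsc1-c1cncc(Cl)c1N1CCC2(CCNC2=O)CC1` has 3-methylthiophen-2-yl in place of 5-formylfuran-2-yl on an aromatic carbon of the six-membered aromatic ring with 1 nitrogen (3-methylthiophen-2-yl in place of 5-formylfuran-2-yl on an aromatic carbon). Among the measured compounds shown here, only one measured step bears on this, a 1.0-fold higher number from compound 1 to compound 2 (0.02 log units; within the scatter), and it puts formyl in place of methyl on an aromatic carbon. For the measured compounds named here, that step shows the value in this assay holding still across that one exchange, but no measured step replaces the whole five-membered ring. A step beyond the scatter is therefore not expected, and no direction is favoured, though the uncertainty is wide. The expected change is a 1.3-fold lower number from compound 2 to compound 3 (0.11 log units; within the scatter). For compound 3 the estimated value is 4000 nM, with an expected range from 1200 nM to 13000 nM.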

Compound 3, concentration for 50% growth inhibition: 910 nM
Estimate against measurement, compound 3: 4.4-fold (0.64 log units) above, and the stated range ends above it.
By their numbers in this assay, from the lowest: compound 3; then compounds 1 and 2 (each within the scatter of the next).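

At this position, on an aromatic carbon of a six-membered aromatic ring with 1 nitrogen, this assay responded to exchange of the whole five-membered ring, although the change from methyl to formyl had left the value level within the scatter. Placing 3-methylthiophen-2-yl in the position of 5-formylfuran-2-yl gave a 5.7-fold lower number from compound 2 to compound 3 (0.76 log units; beyond the scatter) and placing it in the position of 5-methylfuran-2-yl gave a 5.4-fold lower number from compound 1 to compound 3 (0.74 log units; beyond the scatter), so both furans gave way to the same clear gain in growth inhibition. No available evidence accounts for this gain.

The exchange alters the ring hetero atom and the substituent and its place together, and the compounds shown do not separate these changes. They also leave open how an unsubstituted thiophene, a phenyl ring or an aminomethyl group on the five-membered ring would read.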